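Replacing the acyl sulfonamide with a glycine-type amide

The compounds below may be only part of what the source reports. "The series", "measured", "known", "first", "only" and "open" are said of these compounds alone.

Measured compounds:
compound 1 `O=C(O)c1ccc(N2CCC3(CC2)CC(OCc2c(-c4ccccc4OC(F)(F)F)noc2C2CC2)CO3)nc1` — 7.9 nM
compound 2 `CS(=O)(=O)NC(=O)c1ccc(N2CCC3(CC2)CC(OCc2c(-c4ccccc4OC(F)(F)F)noc2C2CC2)CO3)nc1` — 26.9 nM

In an assay on isolated protein for agonist activity at Bile acid receptor (Homo sapiens), read by TR-FRET, with a stated time of 180 min (a lower number here means that less compound is needed, a higher number that more compound is needed for the effect), compound 1 gives 7.9 nM. Compound 2 carries a methanesulfonamido group in place of the hydroxy on the carbonyl carbon, and in this assay compound 2 gives 26.9 nM. Within the data shown here, that single measured step, a 3.4-fold higher number from compound 1 to compound 2 (0.53 log units; beyond the scatter), places compound 2 at the higher of the two numbers so far.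

Compound 3 `O=C(O)CNC(=O)c1ccc(N2CCC3(CC2)CC(OCc2c(-c4ccccc4OC(F)(F)F)noc2C2CC2)CO3)nc1` is not yet measured. It differs from compound 2 by carboxymethyl in place of methylsulfonyl on an amide-type nitrogen. Among the measured compounds shown here, only one step bears on this change, the one from compound 1 to compound 2, and it was modest in size. The carboxylic acid of compound 1 is absent in compound 2 but returns in compound 3, moved one unit further from the shared core and linked through an amide. For the measured compounds named here, the data give no closer precedent, so the change is expected to stay near the measured spread: compound 3 is estimated at 18 nM, within 5 nM to 70 nM, with the expected step of a 1.5-fold lower number from compound 2 to compound 3 (0.17 log units; within the scatter) lying in the direction of compound 1.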

Compound 3, half-maximal effective concentration: 1.7 nM
Compound 3: the middle estimate sits 11-fold (1.02 log units) above what was measured; measured number below the stated range.
By their numbers in this assay, from the lowest: compound 3; then compound 1; then compound 2.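

In this assay, the substituent on the amide-type nitrogen proves to matter a great deal: carboxymethyl in place of methylsulfonyl gives a 16-fold lower number from compound 2 to compound 3 (1.20 log units; beyond the scatter), the largest step among the three compounds. Extension at the carbonyl carbon also need not raise the number, as the earlier methanesulfonamido step alone might have suggested: (carboxymethyl)amino in place of hydroxy gives a 4.6-fold lower number from compound 1 to compound 3 (0.67 log units; beyond the scatter), leaving compound 3 with the lowest number of the three. No measurement is available to explain why these groups differ so sharply.

The compounds shown leave open whether the carboxylic acid at the end of the carboxymethyl group is needed, a question that a methyl ester or a primary amide at the same place would help to answer. They also leave open how the number responds to chain length and branching, for example with a carboxyethyl group or a methyl branch on the carboxymethyl chain.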